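The source may report more compounds than this note shows. Statements on the series, on what has been measured and on what is new or still open speak of the compounds shown alone.

Measured so far:
Compound 1, `CCOC(=O)/C=C/c1ccncc1-c1ccc2ccccc2c1`: 53.3 nM
Compound 2, `NC(=O)/C=C/c1ccncc1-c1ccc2ccccc2c1`: 10.5 nM

In an assay on a protein complex for inhibition of CDK8/Cyclin C (Homo sapiens), with a stated time of 1 h (a higher number here means a weaker inhibitor, a lower number a stronger inhibitor), compound 2 gives the lowest of the two numbers obtained. Going by the values given here, its nearest neighbour is compound 1, and the one step between them, a 5.1-fold lower number from compound 1 to compound 2 (0.71 log units; beyond the scatter), came from putting an amino group in place of an ethoxy group on a carbonyl carbon, which means both compounds share the same core and differ only at the far end of the side chain.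

Compound 3, `O=C(O)CCc1ccncc1-c1ccc2ccccc2c1`, has not been measured yet. It differs from compound 2 in that (2-carboxyethyl in place of 2-carbamoylethenyl on an aromatic carbon). This touches the same side chain as the step from compound 1 to compound 2, but the change is of another kind: the double bond outside the aromatic rings is lost and the carbamoyl end becomes a carboxy end. The measured step shows that this chain end can shift the number modestly, so a step of similar size is plausible. Compound 3 is therefore expected to give a higher number than compound 2, an estimated 11-fold higher number from compound 2 to compound 3 (1.06 log units; beyond the scatter), with compound 3 expected at 120 nM and a likely range from 30 nM to 500 nM.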

Compound 3, half-maximal inhibitory concentration: 50.5 nM
The estimate for compound 3 lay 2.4-fold (0.38 log units) above the measured number, and the stated range covers the measured number.
By their numbers in this assay, from the lowest: compound 2; then compounds 3 and 1 (each within the scatter of the next).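

In this assay, replacing the 2-carbamoylethenyl group of compound 2 with 2-carboxyethyl gives a 4.8-fold higher number from compound 2 to compound 3 (0.68 log units; beyond the scatter), so this position responds to a change that both removes the carbon-carbon double bond of the chain and turns the amide end into a carboxylic acid. The comparison with the ethyl ester adds something new: a 1.1-fold lower number from compound 1 to compound 3 (0.02 log units; within the scatter) shows that the 2-carboxyethyl chain and the 2-(ethoxycarbonyl)ethenyl chain cannot be told apart in this assay, although they differ in both the chain and its end, and compound 2 remains the only one of the three set apart by a step beyond the scatter. No measurement available here accounts for these numbers.

As far as these compounds go, the two changes in compound 3 come together, so how much of its step belongs to the lost carbon-carbon double bond and how much to the new chain end remains open. From the compounds shown here alone, a 2-carbamoylethyl chain or a 2-carboxyethenyl chain would separate the two, while the effect of a longer chain or an amine at the chain end also remains unknown.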